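The source may report more compounds than this note shows. Statements on the series, on what has been measured and on what is new or still open speak of the compounds shown alone.

Measured compounds:
compound 1 `Cc1ccc(-c2cc3ncn([C@H]4CCN(C(=O)N(C)[C@H]5CCN(C6CCOCC6)C5)C4)c(=O)c3s2)cc1`: 14 nM
compound 2 `Cc1ccc(-c2cc3ncn([C@H]4CCN(C(=O)N(C)[C@H]5CCN(C6CCOCC6)C5)C4)c(=O)c3s2)c(C)c1`: 70 nM

Both compounds were tested in an assay on isolated protein for binding affinity to melanin-concentrating hormone receptor 1 (Homo sapiens); on this read-out higher numbers stand for weaker inhibition and lower numbers for stronger inhibition. Compound 1 gives 14 nM, and compound 2 gives 70 nM. Going by the values given here, compound 2 therefore stands at the higher of the two numbers, the weaker of the pair, and the single step from compound 1 to compound 2, a 5.0-fold higher number from compound 1 to compound 2 (0.70 log units; beyond the scatter), came from one added methyl on the aromatic ring.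

Compound 3 `CN(C(=O)N1CC[C@H](n2cnc3cc(-c4ccc(C(F)(F)F)cc4)sc3c2=O)C1)[C@H]1CCN(C2CCOCC2)C1` is not yet measured. It differs from compound 2 in one place: 4-(trifluoromethyl)phenyl in place of 2,4-dimethylphenyl on an aromatic carbon. Two things happen at once here: both methyls leave, and a trifluoromethyl takes the place of one of them. The step from compound 1 to compound 2 bears on the first part, since it shows what one of those methyls was worth: removing it again should undo that rise. Among the compounds with values here, for the exchange of methyl against trifluoromethyl on the same ring, no measured pair gives guidance. The expectation in this assay is therefore a fall, a 3.5-fold lower number from compound 2 to compound 3 (0.54 log units; beyond the scatter), back toward compound 1, with wide uncertainty. Compound 3 is estimated at 20 nM, between 5 nM and 80 nM.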

Compound 3, inhibition constant: 19 nM
For compound 3 the middle estimate is 1.1-fold (0.02 log units) above the measured one; measured number inside the range.
By their numbers in this assay, from the lowest: compounds 1 and 3 (each within the scatter of the next); then compound 2.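

In this assay, replacing 2,4-dimethylphenyl with 4-(trifluoromethyl)phenyl on the aromatic carbon next to the ring sulfur gives a 3.7-fold lower number from compound 2 to compound 3 (0.57 log units; beyond the scatter), so the number measured with the two methyls does not hold once that ring carries a single group. Going by these compounds alone, the closer comparison is the exchange of methyl for trifluoromethyl, which gives a 1.4-fold higher number from compound 1 to compound 3 (0.13 log units; within the scatter), and this shows that this read-out does not separate these two groups on this ring, even though the entering aryl group has more heavy atoms than the one in compound 1. No accompanying measurement speaks to what lies behind these numbers.

From the compounds shown here alone, it remains open whether other single groups on this ring, such as a chlorine, a methoxy or a nitrile, would also read like compound 1 and compound 3, or whether a plain phenyl with no added group would do so. Going by these compounds, it is also open whether the second methyl of compound 2 would carry the same penalty on a ring that also holds a trifluoromethyl.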